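The compounds below may be only part of what the source reports. "The series", "measured", "known", "first", "only" and "open" are said of these compounds alone.

Working notes on the series. Among the measured compounds shown here, the three measured members share one core, and every number so far is a limit. In an assay on isolated protein (Cricetulus griseus) for binding affinity to Alpha-1B adrenergic receptor (Mesocricetus auratus), read by radioligand binding (a lower number here means a stronger inhibitor, a higher number a weaker inhibitor), compound 1 `CCS(=O)(=O)Nc1cc(Cl)cc2c1CCCC2c1c[nH]cn1` gives only a limit, < 10000 nM. Compound 2 `CS(=O)(=O)Nc1ccc(O)c2c1CCCC2c1c[nH]cn1` likewise returns only a limit in this assay, < 10000 nM. Compound 3 `COc1ccc(NS(C)(=O)=O)c2c1C(c1c[nH]cn1)CCC2` carries methyl in place of hydrogen on an oxygen on an aromatic ring relative to compound 2. In this assay compound 3 again returns only a limit, < 10000 nM. The step that the two limits leave unreadable from compound 2 to compound 3 is therefore unreadable, two limits bracketing nothing. Where compound 3 stands is known only as a limit, and the two further values shown are limits as well; that is the whole of the evidence, (the limit of < 10000 nM in this assay, at which 3 of the 3 values shown sit).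

Compound 4 `Cc1ccc(NS(C)(=O)=O)c2c1C(c1c[nH]cn1)CCC2` follows, differing from compound 3 by methyl in place of methoxy on an aromatic carbon. For the measured compounds named here, no measured step bears on this change: the one step available, a step that the two limits leave unreadable from compound 2 to compound 3, lies between two limits and has no readable size. No step beyond the scatter can be expected in this assay, and the expected step that the limit leaves unreadable from compound 3 to compound 4 rests on nothing firmer than the limits themselves. For compound 4 the estimate is 3000 nM, with a range from 300 nM to 10000 nM, and a limit rather than a number remains the likeliest report.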

Compound 4, inhibition constant: < 10000 nM
Compound 4: only a limit was reported (the forecaster's own chance of this, stated with the estimate: 70%); the middle value does not contradict the limit.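

In this assay compound 4 returns only a limit, < 10000 nM. No step from compound 2 or compound 3 to compound 4 can be read, since the series sits at one limit: the limit of < 10000 nM in this assay, at which 4 of the 4 values shown sit.

The compounds shown leave open whether hydroxy, methoxy and methyl at this place differ at all in this assay.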